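Saturating the acyl chain on the free-hydroxyl core

The compounds below may be only part of what the source reports. "The series", "measured", "known", "first", "only" and "open" are said of these compounds alone.

In a functional assay on HT-22 cells (Mus musculus), read by MTT assay, with stated times of 2 h, 20 h and 4 h (on this read-out higher numbers stand for an effect only at larger amounts of compound and lower numbers for an effect already at smaller amounts), compound 3 `CCCCC/C=C\C/C=C\CCCCCCCC(=O)NCCCCCC(=O)OCC(O)C1OC(=O)C(O)=C1O` gives 6400 nM, the second highest of the three numbers measured. Its nearest neighbour is compound 2 `CCCCC/C=C/C/C=C/CCCCCCCC(=O)NCCCCCC(=O)OCC(O)C1OC(=O)C(OCc2ccccc2)=C1OCc1ccccc1`, which gives 8200 nM, within the scatter of compound 3; the furthest is compound 1 `CCCCCCCCCCCCCCCCCC(=O)NCCCCCC(=O)OCC(O)C1OC(=O)C(OCc2ccccc2)=C1OCc1ccccc1`, which gives 2500 nM, a number beyond the scatter below that of compound 3.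

Compound 4 `CCCCCCCCCCCCCCCCCC(=O)NCCCCCC(=O)OCC(O)C1OC(=O)C(O)=C1O` differs from compound 3 by one change: decyl in place of deca-1,4-dien-1-yl on a saturated chain carbon, seven bonds along the chain from a carbonyl carbon. Among the measured compounds shown here, the only measured step that bears on it is the same exchange run in the opposite direction on the dibenzylated core, a 3.3-fold higher number from compound 1 to compound 2 (0.52 log units; beyond the scatter). There the unsaturated chain raised the number modestly; the reverse, saturating the chain, is therefore expected to lower it by a comparable amount, though this rests on a single pair and the core of compound 3 carries free hydroxyls where compound 1 and compound 2 carry benzyl ethers.

The estimate for compound 4 in this assay is therefore 1900 nM, a step of a 3.4-fold lower number from compound 3 to compound 4 (0.53 log units; beyond the scatter), with an expected range from 800 nM to 5000 nM.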

Compound 4, half-maximal effective concentration: 1800 nM
Estimate against measurement, compound 4: 1.1-fold (0.02 log units) above, within the range that was stated.
By their numbers in this assay, from the lowest: compounds 4 and 1 (each within the scatter of the next); then compounds 3 and 2 (each within the scatter of the next).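

With the free hydroxyls on the shared core, the exchange of deca-1,4-dien-1-yl for decyl on a saturated chain carbon, seven bonds along the chain from a carbonyl carbon, gives in this assay a 3.6-fold lower number from compound 3 to compound 4 (0.55 log units; beyond the scatter) as its reading. Set against a 3.3-fold higher number from compound 1 to compound 2 (0.52 log units; beyond the scatter) on the dibenzylated core, which runs the same exchange in the opposite direction, this shows that in both of these pairs the decyl compound carries the lower number, each step beyond the scatter, so the link between this change and the read-out is not confined to the core bearing benzyl ethers. Nothing given here accounts for why the saturated chain goes with the lower number.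

The double bonds are drawn with opposite geometry in compound 2 and compound 3, so the compounds shown leave open how the two geometries compare on a single core, and whether one double bond alone would behave as the diene or as the decyl chain does. They also leave open whether a longer chain, a shorter chain or a chain ending in a carboxylic acid would carry the same relationship further at this position.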